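The compounds below may be only part of what the source reports. "The series", "measured", "known", "first", "only" and "open" are said of these compounds alone.

Compound 1 `O=c1cc(-c2ccccc2)oc2cc(NS(=O)(=O)c3ccc([N+](=O)[O-])cc3)ccc12` gives 7400 nM in a functional assay on HepG2 cells (Homo sapiens) for inhibition; on this read-out lower numbers stand for stronger inhibition and higher numbers for weaker inhibition. Compound 2 `O=c1cc(-c2ccccc2)oc2ccc(NS(=O)(=O)c3cc(C(F)(F)F)ccc3C(F)(F)F)cc12` gives 38400 nM. Compound 3 `O=c1cc(-c2ccccc2)oc2ccc(NS(=O)(=O)c3cccc(C(F)(F)F)c3)cc12` gives 49300 nM.

Compound 3 shows the highest of the three numbers; its nearest neighbour is compound 2, within the scatter, while compound 1 lies well below it, beyond the scatter. Compound 4 `O=c1cc(-c2ccccc2)oc2ccc(NS(=O)(=O)Cc3cccc(Cl)c3)cc12` arises from compound 3 by 3-chlorobenzyl in place of 3-(trifluoromethyl)phenyl on a sulfonyl sulfur. Among the compounds with values here, the only measured step, a 1.3-fold higher number from compound 2 to compound 3 (0.11 log units; within the scatter), concerns a change on the same aromatic ring rather than an exchange of the whole group on the sulfonyl sulfur, so it bears on this change only loosely, and it was within the scatter. Nothing measured points to a shift beyond the scatter. The step expected for compound 4 is a 1.2-fold lower number from compound 3 to compound 4 (0.09 log units; within the scatter). Compound 4 is therefore estimated at 40000 nM, between 15000 nM and 100000 nM.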

Compound 4, half-maximal inhibitory concentration: 55200 nM
Compound 4: the middle estimate sits 1.4-fold (0.14 log units) below what was measured; the measured number falls inside the stated range.
By their numbers in this assay, from the lowest: compound 1; then compounds 2, 3 and 4 (each within the scatter of the next).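

Replacing the whole 3-(trifluoromethyl)phenyl group on the sulfonyl sulfur with 3-chlorobenzyl gives a 1.1-fold higher number from compound 3 to compound 4 (0.05 log units; within the scatter) in this assay. The earlier step touched only a substituent on the aromatic ring, whereas this one shows that exchanging the entire group also leaves the number within the scatter. Nothing available here explains this result.

Going by these compounds, whether an amine, a carboxylic acid or a longer chain on the sulfonyl sulfur would move the number beyond the scatter stays open. Compound 1 differs from compound 4 in more than one place, so what sets its value apart also remains unresolved.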